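Removing one chloro from compound 1: a step expected flat

A few compounds are considered here, and "the series" means these few. Any claim that something is new, unique, unknown or untested is made for them only; others in the source may bear on it.

Of the compounds shown here, two have numbers so far. Going by the values given here, in a functional assay on the whole organism (Pleural cavity) for inhibition, with Rattus norvegicus as the target, at a dose of 25 mg/kg (a higher number here means more inhibition at the dose given (going by the name of the read-out), a lower number less inhibition), compound 1 `CC1(C)C(=O)N(c2ccc(Cl)cc2Cl)c2ncccc21` gives 8%, and compound 2 `CC1(Sc2ccccc2)C(=O)N(c2ccccc2)c2ncccc21` gives 0% in this assay; the two values lie within the scatter of each other, so compound 1 stands level with the only other measured compound, and neither number can be called the higher. Compound 3 `CC1(C)C(=O)N(c2ccccc2Cl)c2ncccc21` differs from compound 1 by hydrogen in place of chloro on an aromatic carbon, on an aromatic carbon of a six-membered aromatic ring of carbon only, meta to a chloro group and para to a large group. Among the compounds with values here, no measured pair shows this change, so its size is unknown; with both measured values already low and level, the change is expected to give no step beyond the scatter in this assay, in either direction. Compound 3 is expected to give 6% (range -5% to 20%), an expected step of a number 2 percentage points lower from compound 1 to compound 3 (within the scatter).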

Compound 3, a percentage reported as inhibition, in the whole organism at one dose (the size of the read-out at that dose, not a potency): 3%
Beside the measured number, compound 3's estimate is 3 percentage points above it, and the stated range covers the measured number.
By their numbers in this assay, from the lowest: compounds 2, 3 and 1 (each within the scatter of the next).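

Going by these compounds alone, compound 1 and compound 3 form the first pair that differs in one place, so this position can now be read directly. In this assay, hydrogen in place of chloro on an aromatic carbon, meta to a chloro group and para to a large group, gives a step of a number 5 percentage points lower from compound 1 to compound 3 (within the scatter), so this chloro makes no difference that can be told from the scatter here. No measurement of any property of these compounds bears on this result.

With both values low, the pair cannot show whether this position matters in a compound with a larger read-out, and a single dose gives no potency. As far as these compounds go, it remains open whether an amine, a methoxy group or a carboxylic acid on this aromatic carbon would move the read-out beyond the scatter, and what replacing the remaining chloro would do.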